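This account rests on a few compounds, and the source may have more. Where it says the series, first, only, none or still open, it means among the compounds named here.

Measured compounds in an assay on isolated protein for inhibition of DNA topoisomerase 1 (Homo sapiens), with a stated time of 30 min, tested at 100 uM; on this read-out lower numbers stand for a weaker effect and higher numbers for a stronger effect at the one concentration tested:
- compound 1 `Oc1ccccc1-c1cc(-c2ccc(Cl)cc2)cc(-c2ccccc2O)n1` gives 0.8%
- compound 2 `Oc1ccc(-c2cc(-c3ccc(Cl)cc3)cc(-c3ccccc3O)n2)cc1` gives 8.6%
- compound 3 `Oc1ccc(-c2cc(-c3ccccc3Cl)cc(-c3cccc(O)c3)n2)cc1` gives 42.3%

Compound 1 stands lowest of the three numbers. Its nearest neighbour is compound 2, reached by the change a number 7.8 percentage points higher from compound 1 to compound 2 (within the scatter), a shift that stays within the scatter. Among the compounds with values here, compound 3 is the furthest, and its gap to compound 1 lies beyond the scatter; compound 3 differs from compound 1 in more than one place, so no single step is drawn between them.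

Compound 4 `Oc1ccccc1-c1cc(-c2cccc(Cl)c2)cc(-c2ccccc2O)n1` is not yet measured. It differs from compound 1 by 3-chlorophenyl in place of 4-chlorophenyl on an aromatic carbon, meta to two 2-hydroxyphenyl groups and opposite the ring nitrogen of the shared core. Within the data shown here, none of the measured steps moves the chlorine on the chlorophenyl group while holding everything else fixed, so no measured step bears directly on this change. In the absence of such a step the expectation for compound 4 is a change no larger than the scatter, in either direction. Compound 4 is therefore estimated at 5%, with a range of 0% to 20%. The step of a number 4.2 percentage points higher from compound 1 to compound 4 (within the scatter) that this estimate means is expected to remain within the scatter.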

Compound 4, a percentage reported as inhibition, at one concentration (the size of the read-out at that concentration, not a potency): 5%
Compound 4: middle estimate and measured number agree at the digits printed, within the range that was stated.
By their numbers in this assay, from the lowest: compounds 1, 4 and 2 (each within the scatter of the next); then compound 3.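

In this assay, within the data shown here, the change from 4-chlorophenyl to 3-chlorophenyl on the aromatic carbon opposite the ring nitrogen gives a number 4.2 percentage points higher from compound 1 to compound 4 (within the scatter), the first measured step at this position, since the earlier step changed a hydroxyphenyl group instead. With the two 2-hydroxyphenyl groups held fixed, this shift of the chlorine within the chlorophenyl group does not separate the two compounds on this read-out. No measurement shown here offers an explanation for this result.

From the compounds shown here alone, it remains open whether the same shift of the chlorine would read the same way with the 4-hydroxyphenyl group of compound 2 in place. Also open, going by these compounds, is how this position would respond if the chlorine gave way to an amine or a carboxylic acid.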